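From Fluoro to Chloro on an Aromatic Ring

This account rests on a few compounds, and the source may have more. Where it says the series, first, only, none or still open, it means among the compounds named here.

Compound 1 `C=C1C(=O)[C@@]23C(=O)OC[C@]4(C(=O)CCC(C)(C)[C@H]4C=O)[C@@H]2CC[C@@H]1[C@H]3OC(C)=O`: 1660 nM
Compound 2 `C=C1C(=O)[C@@]23C(=O)OC[C@]4(C(=O)CCC(C)(C)[C@H]4C=O)[C@@H]2CC[C@@H]1[C@H]3OC(=O)CC`: 1780 nM
Compound 3 `C=C1C(=O)[C@@]23C(=O)OC[C@]4(C(=O)CCC(C)(C)[C@H]4C=O)[C@@H]2CC[C@@H]1[C@H]3OC(=O)c1ccc(F)cc1`: 3960 nM

These values come from a functional assay on MGC-803 cells (Homo sapiens) for cytotoxicity, read by MTT assay, with a stated time of 72 h; on this read-out lower numbers stand for stronger inhibition and higher numbers for weaker inhibition. The three compounds share a core and differ only in the group on one carbonyl carbon. Among them, compound 3 has the highest number, 3960 nM, and therefore the weakest inhibition.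

Compound 4 `C=C1C(=O)[C@@]23C(=O)OC[C@]4(C(=O)CCC(C)(C)[C@H]4C=O)[C@@H]2CC[C@@H]1[C@H]3OC(=O)c1ccc(Cl)cc1` differs from compound 3 in one place: chloro in place of fluoro on an aromatic carbon, para to a large group (chloro in place of fluoro on an aromatic carbon).

Within the data shown here, no measured step exchanges one halogen for another, so the evidence is only indirect. The two small chains compare as a 1.1-fold higher number from compound 1 to compound 2 (0.03 log units; within the scatter). Placing 4-fluorophenyl on the carbonyl carbon gives a 2.4-fold higher number from compound 1 to compound 3 (0.38 log units; beyond the scatter) when it replaces methyl and a 2.2-fold higher number from compound 2 to compound 3 (0.35 log units; beyond the scatter) when it replaces ethyl. Even these exchanges of a whole group produced only modest steps, and compound 4 keeps the aromatic ring.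

The expected change is small, with no direction clearly favoured and nothing beyond the scatter anticipated in this assay: a 1.0-fold lower number from compound 3 to compound 4 (0.02 log units; within the scatter). For compound 4 the estimated value is 3800 nM, with an expected range from 1900 nM to 7500 nM.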

Compound 4, half-maximal inhibitory concentration: 3120 nM
Compound 4: the middle estimate sits 1.2-fold (0.09 log units) above what was measured, and the stated range covers the measured number.
By their numbers in this assay, from the lowest: compounds 1, 2, 4 and 3 (each within the scatter of the next, the first and the last beyond it).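

In this assay, among these compounds, this is the first direct exchange of one halogen for another on the aromatic ring, and a 1.3-fold lower number from compound 3 to compound 4 (0.10 log units; within the scatter) stays within the scatter, so fluoro and chloro at this place cannot be told apart here. The result also softens the earlier picture: the 4-fluorophenyl compound lay beyond the scatter of both small-chain esters, yet a 1.8-fold higher number from compound 2 to compound 4 (0.24 log units; within the scatter) and a 1.9-fold higher number from compound 1 to compound 4 (0.27 log units; within the scatter) both remain within it. The gap between small chains and a halogen-bearing aromatic ring on this carbonyl carbon therefore sits close to the edge of the scatter and is not a firm difference across both halogens, and nothing measured here gives a reason for these numbers.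

Still open, on these data alone, is whether a different group on the same aromatic carbon, such as bromo, methoxy or an amine, would shift the number beyond the scatter. A phenyl ring with no halogen, or a longer chain on the carbonyl carbon, could show more clearly whether small chains and aromatic rings truly differ at this position.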